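Three Distant Swaps Leave the Acid Dissociation Constant Unmoved

The source may report more compounds than this note shows. Statements on the series, on what has been measured and on what is new or still open speak of the compounds shown alone.

Three compounds share one core, a chain with an amine in it, and differ only in the group carried on an aromatic carbon of that core. Compound 1 `COc1ccc(-c2ccc3c(NCCCNCc4cc(F)ccc4OC)ccnc3c2)cc1` gives 9.47 in a physicochemical assay for acid dissociation. Compound 2 `COc1ccc(F)cc1CNCCCNc1ccnc2cc(Oc3ccc(C(C)(C)C)cc3)ccc12` gives 9.28 in this assay, and compound 3 `COc1ccc(F)cc1CNCCCNc1ccnc2cc(Cc3ccc(F)cc3)ccc12` gives 9.47 in this assay. None of the changes among them moved the number beyond the usual scatter: a number 0.19 log units lower from compound 1 to compound 2 (within the scatter), no change at the digits printed from compound 1 to compound 3 (within the scatter) and a number 0.19 log units higher from compound 2 to compound 3 (within the scatter).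

Compound 3 thus stands level with compound 1 at the digits shown, the two of them together the highest of the three numbers, while compound 2 sits a little lower but still within the scatter of both.

Compound 4 `COc1ccc(F)cc1CNCCCNc1ccnc2cc(-c3ccccc3)ccc12` is the next step from compound 3: phenyl in place of 4-fluorobenzyl on an aromatic carbon. The three measured steps bear on this change, since each also replaced the group on that same aromatic carbon, and each stayed within the scatter. The same outcome is expected here, so the step of a number 0.05 log units lower from compound 3 to compound 4 (within the scatter) is estimated to be no change beyond the scatter. Compound 4 is therefore expected to give 9.42 in this assay, with a range from 9.1 to 9.75.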

Compound 4, acid dissociation constant: 9.47
Estimate against measurement, compound 4: 0.05 log units below, and the stated range covers the measured number.
By their numbers in this assay, from the lowest: compounds 2, 1, 3 and 4 (each within the scatter of the next).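

In this assay, compound 4 shows that the group on this aromatic carbon can be a phenyl ring with nothing on it. For the compounds shown here, all the earlier compounds carried a substituted ring here, yet replacing 4-fluorobenzyl with the smaller phenyl gives no change at the digits printed from compound 3 to compound 4 (within the scatter). Removing only the methoxy, the simplest edit of the set, gives no change at the digits printed from compound 1 to compound 4 (within the scatter), and replacing 4-(tert-butyl)phenoxy with phenyl gives a number 0.19 log units higher from compound 2 to compound 4 (within the scatter), so no swap at this carbon among the four compounds goes beyond the scatter, though no measurement shown here accounts for this flat result.

Going by these compounds, every group at this carbon so far is built on a six-membered aromatic ring of carbon only, so it remains open whether a carboxylic acid or a primary amine on that ring, or a plain hydrogen on the carbon itself, would leave the number just as flat. On these data alone, the chain with the amine is the same in all four compounds, so the effect of a longer chain there, or of a change on its 2-methoxy-5-fluorobenzyl end, also remains open.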